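Indole glyoxylamides: methyl for 1-methoxy-1-methylethyl on the chain

A few compounds are considered here, and "the series" means these few. Any claim that something is new, unique, unknown or untested is made for them only; others in the source may bear on it.

The series shares a glyoxylamide linking a core to a methoxypyridine amine; the cores differ in ring substitution and in the group on the aromatic nitrogen. Compound 1 is `COCCn1cc(C(=O)C(=O)Nc2ccc(OC)nc2)c2cc(Cl)ccc21`, compound 2 is `COc1ccc(NC(=O)C(=O)c2cn(CC(C)(C)OC)c3ccccc23)cn1` and compound 3 is `COc1ccc(NC(=O)C(=O)c2cn(C(C)C)c3cnccc23)cn1`. In a functional assay on FaDu cells (Homo sapiens) for cytotoxicity, read by MTT assay, with a stated time of 72 h (a lower number here means that less compound is tolerated, a higher number that more compound is tolerated), compound 1 gives only a limit, > 10000 nM. In this assay compound 2 likewise gives only a limit, > 10000 nM. Compound 3 also reaches only a limit in this assay, > 10000 nM. So compound 2 stands where every measured member of the series stands, at the limit of > 10000 nM in this assay, at which 3 of the 3 values shown sit; no value below the limit has been recorded for any of the three, and no step between measured compounds can be sized.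

Compound 4 is `CCn1cc(C(=O)C(=O)Nc2ccc(OC)nc2)c2ccccc21`, not yet tested. It differs from compound 2 by methyl in place of 1-methoxy-1-methylethyl on a saturated chain carbon bound to an aromatic nitrogen. In this assay, with all three measured values sitting at the limit, no direction can be read for this change, and the expectation is for no step beyond the usual scatter; compound 4 is expected at about 15000 nM (range 5000 nM to 50000 nM), an estimated step that the limit leaves unreadable from compound 2 to compound 4, most likely reported again only as a limit.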

Compound 4, concentration lethal to 50% of the cells: 219 nM
Estimate against measurement, compound 4: 68-fold (1.84 log units) above; measured number below the stated range.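

In this assay, the group on a saturated chain carbon bound to an aromatic nitrogen proves able to move the read-out: methyl in place of 1-methoxy-1-methylethyl gives an at least 45-fold lower number from compound 2 to compound 4 (1.65 log units; beyond the scatter). Among these compounds, for compound 2 the value > 10000 nM is a limit of the assay, so the step has a lower bound but no full size, and the change, which also reads as 2-methoxy-2-methylpropyl to ethyl, is the first one with a readable direction. Compound 4, at 219 nM, is the only compound shown with a measured number. The rest of the set stays at the limit: the limit of > 10000 nM in this assay, at which 3 of the 4 values shown sit.

Among the compounds shown here, the single pair does not separate the loss of the oxygen from the loss of the carbons, since both leave together in this change; a propyl chain or a 2-methoxyethyl chain on the core of compound 4 would divide the two. On these data alone, how far the trend runs in the other direction is also open, as is whether an amine at the end of a longer chain on that nitrogen would be tolerated in the same way as ethyl.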